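Working notes: sulfur substituents, compound 3 to compound 4

The compounds below may be only part of what the source reports. "The series", "measured", "known", "first", "only" and "open" are said of these compounds alone.

Compound 1 `CC(C)c1n[nH]c2c(NCc3ccc(-c4ccccn4)cc3)nc(SCC(O)C(F)(F)F)nc12`: 690 nM
Compound 2 `CC(C)c1n[nH]c2c(NCc3ccc(-c4ccccn4)cc3)nc(SCCCO)nc12`: 109 nM
Compound 3 `CC(C)c1n[nH]c2c(NCc3ccc(-c4ccccn4)cc3)nc(SCC(C)(C)N)nc12`: 85 nM

All three values come from a functional assay on HT cells (Homo sapiens) for antiproliferative activity, read by fluorescence, with a stated time of 72 h; on this read-out lower numbers stand for stronger inhibition of growth and higher numbers for weaker inhibition of growth. Compound 3 stands at the low end of these numbers, but without separation from its nearest neighbour: the data show a 1.3-fold lower number from compound 2 to compound 3 (0.11 log units; within the scatter). The distance to the high end is larger, with an 8.1-fold lower number from compound 1 to compound 3 (0.91 log units; beyond the scatter).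

The next compound is compound 4 `CC(C)c1n[nH]c2c(NCc3ccc(-c4ccccn4)cc3)nc(SC3CCCCC3O)nc12`. The change on the sulfur is 2-hydroxycyclohexyl in place of 2-amino-2-methylpropyl on a sulfur. Going by the values given here, no measured compound carries a ring at this place, so no measured step reads directly on that feature. The hydroxyl-bearing chains offer the nearest guide, and they span a 6.3-fold lower number from compound 1 to compound 2 (0.80 log units; beyond the scatter). Compound 2 carries such a chain and still gives 109 nM, level with compound 3 within the scatter. A modest rise is therefore expected in this assay, with a wide margin. The expected step is a 2.1-fold higher number from compound 3 to compound 4 (0.33 log units; beyond the scatter). For compound 4 the estimated value is 180 nM, with an expected range from 70 nM to 500 nM.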

Compound 4, concentration for 50% growth inhibition: 636 nM
Compound 4: the middle estimate sits 3.5-fold (0.55 log units) below what was measured; measured number outside the range, above it.
By their numbers in this assay, from the lowest: compounds 3 and 2 (each within the scatter of the next); then compounds 4 and 1 (each within the scatter of the next).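

In this assay, going by these compounds alone, 2-hydroxycyclohexyl is the first ring on this sulfur, and it weakens growth inhibition relative to both open chains that carry a polar end group (a 7.5-fold higher number from compound 3 to compound 4 (0.87 log units; beyond the scatter) and a 5.8-fold higher number from compound 2 to compound 4 (0.77 log units; beyond the scatter)). The step of a 1.1-fold lower number from compound 1 to compound 4 (0.04 log units; within the scatter) puts the ring level with 3,3,3-trifluoro-2-hydroxypropyl, so a hydroxyl does not fix the value by itself: compounds 1, 2 and 4 all carry one, yet only compound 2 stays level with compound 3. Nothing shown here gives a reason for these steps.

Against compound 2, compound 4 brings in the ring and moves the hydroxyl in one change, so the two contributions remain unseparated. From the compounds shown here alone, a plain cyclohexyl, a 2-aminocyclohexyl or a longer chain ending in a carboxylic acid on the sulfur remains open.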